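The compounds below may be only part of what the source reports. "The series", "measured", "known", "first", "only" and "open" are said of these compounds alone.

Measured so far in an assay on cells with Cystic fibrosis transmembrane conductance regulator variant F508del (Homo sapiens) as the target, read by fluorescence, with stated times of 24 h and 30 min; on this read-out higher numbers stand for an effect only at larger amounts of compound and lower numbers for an effect already at smaller amounts:

Compound 1 `NC(=O)C1CCN(c2nc(-c3cccnc3)nc3c2CN(Cc2ccccc2)CC3)CC1` gives 100000 nM.
Compound 2 `NC(=O)CN1CCN(c2nc(-c3cccnc3)nc3c2CN(Cc2ccccc2)CC3)CC1` gives 100000 nM.
Compound 3 `CN(C)CCN1CCN(c2nc(-c3ccncc3)nc3c2CN(Cc2ccccc2)CC3)CC1` gives 100000 nM.

Compound 3 stands level with compounds 1 and 2: the three readings lie within the usual scatter of one another, so none of them can be called stronger or weaker than another. Going by the values given here, the only measured step, no change at the digits printed from compound 1 to compound 2 (within the scatter), swapped one group on the shared core and stayed within the scatter.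

Compound 4 `CN(C)CCN1CCN(c2nc(-c3cccnc3)nc3c2CN(Cc2ccccc2)CC3)CC1` is built from the same atoms as compound 3, joined differently: pyridin-3-yl in place of pyridin-4-yl on an aromatic carbon. Compounds 1 and 2 already carry pyridin-3-yl at that point of the shared core, and both sit at the same level as compound 3. Among the compounds with values here, this step therefore has no measured counterpart of its own, but the measured compounds give no hint that this exchange moves the reading. The expected step is no change at the digits printed from compound 3 to compound 4 (within the scatter), that is, none beyond the scatter. Compound 4 is estimated at 100000 nM, with a range from 30000 nM to 100000 nM.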

Compound 4, half-maximal effective concentration: 100000 nM
Compound 4: middle estimate and measured number agree at the digits printed, within the range that was stated.
By their numbers in this assay, from the lowest: compounds 1, 2, 3 and 4 (each within the scatter of the next).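

In this assay, going by these compounds alone, putting pyridin-3-yl in place of pyridin-4-yl on the aromatic carbon between two ring nitrogen atoms gives no change at the digits printed from compound 3 to compound 4 (within the scatter) and is the first direct reading of this exchange, so moving the ring nitrogen of the pyridine makes no visible difference in this setting. Changes at the other substituent on the shared core also leave the reading flat: (dimethylamino)methyl in place of carbamoyl gives no change at the digits printed from compound 2 to compound 4 (within the scatter) and 4-(2-(dimethylamino)ethyl)piperazin-1-yl in place of 4-carbamoylpiperidin-1-yl gives no change at the digits printed from compound 1 to compound 4 (within the scatter) while bringing in a dimethylamino group. No outside measurement is available to explain these readings.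

With all four compounds at one level, neither position has yet been seen to move the reading. From the compounds shown here alone, whether a phenyl ring or pyridin-2-yl at the aromatic carbon, or a morpholine ring in place of the piperazine, would shift the number remains open.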